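Swapping Isobutyl for Benzyl on a Carbamate Tail

This account rests on a few compounds, and the source may have more. Where it says the series, first, only, none or still open, it means among the compounds named here.

Of the compounds shown here, three built on one framework have been tested in a functional assay on CHO-K1 cells for agonist activity at Glucose-dependent insulinotropic receptor (Homo sapiens), read by cAMP accumulation and immunoassay, with a stated time of 1 h (on this read-out higher numbers stand for larger maximal responses and lower numbers for smaller maximal responses), and a fourth now awaits the same test. Compound 1 `CC(C)COC(=O)N1CCC(Oc2cc(Oc3ccc(/C=C4\SC(=O)NC4=O)cc3)ncn2)CC1` carries an isobutyl group on its carbamate; in this assay compound 1 reaches 51%. Compound 2 `O=C1NC(=O)/C(=C/c2ccc(Oc3cc(OC4CCN(C(=O)OCc5ccccc5)CC4)ncn3)cc2)S1` differs from it in a single spot, (phenyl in place of isopropyl on a saturated chain carbon bound to an oxygen next to a carbonyl group), and in this assay compound 2 reaches 88.3%. That single change produced a number 37.3 percentage points higher from compound 1 to compound 2 (beyond the scatter).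

Compound 3 `CC(C)COC(=O)N1CCC(Oc2cc(Oc3cccc(/C=C4\SC(=O)NC4=O)c3)ncn2)CC1` holds the same atoms as compound 1 joined differently; the difference between the two cores is not broken down here. In this assay compound 3 reaches 62.4%, which sets it above compound 1 and below compound 2.

Compound 4 `O=C1NC(=O)/C(=C/c2cccc(Oc3cc(OC4CCN(C(=O)OCc5ccccc5)CC4)ncn3)c2)S1` stands to compound 3 exactly as compound 2 stands to compound 1: phenyl in place of isopropyl on a saturated chain carbon bound to an oxygen next to a carbonyl group. The place of the change is the same in both pairs, so the change itself is the same. A rise of similar direction is expected, because the earlier step of a number 37.3 percentage points higher from compound 1 to compound 2 (beyond the scatter) was large and beyond the usual scatter. The rise is expected to be somewhat smaller, because compound 3 already gives 62.4% and the maximal response has less room left. The expected step is a number 29.6 percentage points higher from compound 3 to compound 4 (beyond the scatter). Compound 4 is therefore estimated to reach about 92%, with a likely span from 78% to 106%.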

Compound 4, largest response reached (Emax), in percent of the reference or control that the assay uses: 98.3%
Compound 4: middle estimate off by 6.3 percentage points, on the low side; the range from low to high includes it.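

In this assay, changing isobutyl to benzyl on the carbamate of the second core again raised the maximal response, giving a number 35.9 percentage points higher from compound 3 to compound 4 (beyond the scatter). Set beside the earlier step, the gain carried from one core to the other with no size difference that can be told apart: the same change on two cores in this assay, a number 37.3 percentage points higher (beyond the scatter) from compound 1 to compound 2 and a number 35.9 percentage points higher (beyond the scatter) from compound 3 to compound 4, 1.4 percentage points apart, within the scatter of two such steps Within this series, then, the isobutyl-to-benzyl change behaved in a roughly additive way, adding a similar amount whichever of these two cores carried it, but two cores are a small sample: they show neither that the same gain would appear on a third core nor why benzyl gives the larger response, and they say nothing about how the change would behave in any other kind of measurement.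

Going by these compounds, whether the gain needs the aromatic ring of the benzyl group or simply a bigger carbon group remains open, and a cyclohexylmethyl carbamate or a longer chain such as n-hexyl would help to separate the two. Also open, on these data alone, is how far the response depends on the carbamate link itself, a question that a simple amide in its place, or a fluorobenzyl group on the same tail, would begin to address.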